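The compounds below may be only part of what the source reports. "The series", "measured", "known", "first", "only" and "open" are said of these compounds alone.

Measured so far:
compound 1 `CC[C@@H]1C(=O)N(C)c2cnc(-n3ccc4cc(F)ccc43)nc2N1C1CCCC1` — "not active" (no number reported)
compound 2 `CCC1C(=O)N(C)c2cnc(-n3ccc4cc(C(=O)NC)ccc43)nc2N1c1ccn(C)n1` — 6330 nM
compound 3 `CCCCNC(=O)c1ccc2c(ccn2-c2ncc3c(n2)N(c2ccn(C)n2)C(CC)C(=O)N3C)c1` — 4260 nM

In a functional assay on HeLa cells (Homo sapiens) for antiproliferative activity, read by CCK-8 assay, with a stated time of 72 h (on this read-out lower numbers stand for stronger inhibition of growth and higher numbers for weaker inhibition of growth), compound 1 is reported as "not active" (no number reported), so no single number places it. Going by the values given here, compound 2 and compound 3, which carry a carbamoyl group in place of the fluoro and a methylpyrazolyl group in place of the cyclopentyl of compound 1, both give numbers, and the one step between them, a 1.5-fold lower number from compound 2 to compound 3 (0.17 log units; within the scatter), shows that lengthening the chain on the amide nitrogen changed nothing beyond the scatter.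

Compound 4 `CCNC(=O)c1ccc2c(ccn2-c2ncc3c(n2)N(C2CCCC2)[C@H](CC)C(=O)N3C)c1` differs from compound 1 by ethylcarbamoyl in place of fluoro on an aromatic carbon. Among the compounds with values here, no measured step covers this change on the cyclopentyl-bearing core; the only information is indirect, namely that compound 2 and compound 3, both with a carbamoyl group at that position, are weakly active in this assay while compound 1 is not. Going by these compounds, whether the carbamoyl group alone, without the methylpyrazolyl group, is enough to bring a number is unknown, so the estimate is uncertain and a further report of no activity remains possible. Compound 4 is expected to give about 5000 nM in this assay, with a range from 1500 nM to 20000 nM.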

Compound 4, concentration for 50% growth inhibition: 418 nM
Compound 4: middle estimate off by 12-fold (1.08 log units), on the high side; the measured number lies below the stated range.
By their numbers in this assay, from the lowest: compound 4; then compounds 3 and 2 (each within the scatter of the next).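

Compound 1 has no number in this assay, so the change from fluoro to ethylcarbamoyl that leads to compound 4 cannot be read as a step. The compounds shown leave open how the cyclopentyl and methylpyrazolyl groups compare when the carbamoyl chain is the same. No measurement shown here explains the value of compound 4.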